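This account rests on a few compounds, and the source may have more. Where it says the series, first, only, none or still open, it means among the compounds named here.

Working notes, measured in an in vitro ADME assay on microsomes from liver (Homo sapiens) for metabolic stability, tested at 5 uM; on this read-out lower numbers stand for a shorter-lived compound and higher numbers for a longer-lived compound:
- Compound 1 `CC(C)CCn1nc(-c2cccs2)c(O)c(C2=NS(=O)(=O)c3cc(S(C)(=O)=O)ccc3N2)c1=O` gives 0.0933 h.
- Compound 2 `CCC(C)(C)c1nn(CCC(C)C)c(=O)c(C2=NS(=O)(=O)c3cc(NS(C)(=O)=O)ccc3N2)c1O` gives 0.1 h.
- Compound 3 `CS(=O)(=O)Nc1ccc2c(c1)S(=O)(=O)N=C(c1c(O)c(-c3cccs3)nn(CC3CCC3)c1=O)N2` gives > 1 h, a limit of the assay and not a number.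

Compound 3 is the only one of the three without a number, and it stands at the limit: the limit of > 1 h in this assay, at which 1 of the 3 values shown sits. Compound 1 at 0.0933 h and compound 2 at 0.1 h sit close to each other. Within the data shown here, both differ from compound 3 in more than one place, so no measured pair isolates a single change.

Next in line is compound 4 `CC(C)(C)Cn1nc(-c2cccs2)c(O)c(C2=NS(=O)(=O)c3cc(NS(C)(=O)=O)ccc3N2)c1=O`, which keeps the core of compound 3 and has tert-butyl in place of cyclobutyl on a saturated chain carbon bound to an aromatic nitrogen. The same difference reads cyclobutylmethyl to neopentyl.

Among the measured compounds shown here, no measured step bears on this change, so no step beyond the usual scatter is expected in this assay, and no direction is favoured. The expectation starts from compound 3, whose > 1 h is a limit. The estimated step is a number no higher from compound 3 to compound 4 (the limit leaves the size open). The read-out may well come back as a limit again. The expected half-life of compound 4 is 1 h, with an estimated range of 0.4 h to 2 h.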

Compound 4, half-life: > 1 h
Compound 4: a limit, no number; the forecaster's own chance of this, stated with the estimate: 55%; the middle value sits exactly at the limit.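

In this assay compound 4 gives > 1 h, a limit of the assay and not a number. Compound 3 gives > 1 h, also a limit. No step can be read between compound 3 and compound 4. The compounds shown leave open whether tert-butyl in place of cyclobutyl on this saturated chain carbon alters the half-life at all.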